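Swapping the ring on the amine of compound 1

The source may report more compounds than this note shows. Statements on the series, on what has been measured and on what is new or still open speak of the compounds shown alone.

Going by the values given here, compound 1 `CO[C@H]1CC[C@@H](CNc2cc(NCc3cnccc3C(F)(F)F)ncc2C#N)CC1` is the weakest of the three compounds measured so far. In an assay on isolated protein for inhibition of protein kinase C delta type (Homo sapiens), read by TR-FRET, with a stated time of 2 h (on this read-out higher numbers stand for weaker inhibition and lower numbers for stronger inhibition), compound 1 gives 5000 nM. Compound 2 `N#Cc1cnc(NCc2ccccc2C(F)(F)F)cc1N[C@H]1CC[C@@H](C(N)=O)CC1` gives 640 nM in this assay, and compound 3 `N#Cc1cnc(NCc2cncnc2-c2ccccc2)cc1N[C@H]1CC[C@@H](O)CC1` gives 90 nM; both numbers lie below that of compound 1, beyond the scatter. Compound 2 and compound 3 each differ from compound 1 in more than one place, so no single step can be read from them. Compound 4 `CC1(C)[C@@H](C(N)=O)C[C@H]1Nc1cc(NCc2cnccc2C(F)(F)F)ncc1C#N` carries 3-carbamoyl-2,2-dimethylcyclobutyl in place of (4-methoxycyclohexyl)methyl on a nitrogen on an aromatic ring. Compound 2 and compound 3 also place a ring with a hydrogen-bond donor directly on that nitrogen, so compound 4 is expected to show a step of a 6.3-fold lower number from compound 1 to compound 4 (0.80 log units; beyond the scatter) toward stronger inhibition, beyond the scatter. The estimate for compound 4 is 800 nM, with a range from 200 nM to 3000 nM.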

Compound 4, half-maximal inhibitory concentration: 160 nM
Estimate against measurement, compound 4: 5.0-fold (0.70 log units) above, outside the stated range (below it).
By their numbers in this assay, from the lowest: compounds 3 and 4 (each within the scatter of the next); then compound 2; then compound 1.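

Going by these compounds alone, on a nitrogen on an aromatic ring, 3-carbamoyl-2,2-dimethylcyclobutyl in place of (4-methoxycyclohexyl)methyl gives a 31-fold lower number from compound 1 to compound 4 (1.49 log units; beyond the scatter) in this assay and is the first single-place comparison here. It shows that this position responds strongly to the group it carries, even though the heavy-atom count stays the same. The six-membered ring gives way to a four-membered one and a hydrogen-bond donor enters, but no measurement here explains the change. The compounds shown do not separate the effects of the ring, the carbamoyl group and the two methyl groups. Also open, on these data alone, is how a carboxylic acid or an amine in place of the carbamoyl group would read.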